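Cyclohexyl substituent swap from methoxy to isopropyl

The compounds below may be only part of what the source reports. "The series", "measured", "known", "first", "only" and "open" are said of these compounds alone.

compound 1, `CC(C)(C)[C@H]1CC[C@H](N(Cc2ccc(C(=O)NCCC(=O)O)cc2)C(=O)Nc2ccc(Cl)c(Cl)c2)CC1`: 226 nM
compound 2, `O=C(O)CCNC(=O)c1ccc(CN(C(=O)Nc2ccc(OC(F)(F)F)cc2)C2CCC(C(=O)NCC3CC3)CC2)cc1`: > 10000 nM
compound 3, `COC1CCC(N(Cc2ccc(C(=O)NCCC(=O)O)cc2)C(=O)Nc2ccc(OC(F)(F)F)cc2)CC1`: > 10000 nM

In an in vitro assay on BHK cells for inhibition of Glucagon receptor (Homo sapiens) (on this read-out lower numbers stand for stronger inhibition and higher numbers for weaker inhibition), compound 1 gives 226 nM. Compound 2 gives only a limit of the assay, > 10000 nM. Compound 3 likewise gives only a limit, > 10000 nM, and so sits at the limit of > 10000 nM in this assay, at which 2 of the 3 values shown sit. The step that the two limits leave unreadable from compound 2 to compound 3 is unreadable from those two limits. Compound 4, `CC(C)C1CCC(N(Cc2ccc(C(=O)NCCC(=O)O)cc2)C(=O)Nc2ccc(OC(F)(F)F)cc2)CC1`, differs from compound 3 in isopropyl in place of methoxy on a saturated ring carbon. Among the measured compounds shown here, no measured step bears directly on this change; the only number in the set belongs to compound 1, which carries tert-butyl rather than methoxy on the saturated ring together with a differently substituted aryl group. Compound 4 is expected to show the step of an at least 6.6-fold lower number from compound 3 to compound 4 (0.82 log units; beyond the scatter). The estimate for compound 4 is 1500 nM, with a range of 250 nM to 10000 nM.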

Compound 4, half-maximal inhibitory concentration: 59 nM
Compound 4: middle estimate off by 25-fold (1.41 log units), on the high side; the whole stated range lies above it.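

In this assay, among the compounds shown here, the change from 4-methoxycyclohexyl to 4-isopropylcyclohexyl gives the first readable step at this saturated ring carbon: an at least 160-fold lower number from compound 3 to compound 4 (2.22 log units; beyond the scatter). Isopropyl in place of (cyclopropylmethyl)carbamoyl on the same carbon gives an at least 160-fold lower number from compound 2 to compound 4 (2.22 log units; beyond the scatter), so the read-out at this position depends strongly on the substituent. Both steps are bounds only: the limit of > 10000 nM in this assay, at which 2 of the 4 values shown sit.

As far as these compounds go, how a hydroxyl, an amine or a longer alkyl chain on this carbon would read remains open. The tert-butyl group of compound 1 comes with a different aryl group, so its contribution cannot be separated.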